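The compounds below may be only part of what the source reports. "The series", "measured", "known", "first", "only" and "open" are said of these compounds alone.

Measured in a functional assay on MCF7 cells (Homo sapiens) for cytotoxicity, read by sulforhodamine B assay, with a stated time of 3 days; a lower number here means a stronger inhibitor, a higher number a weaker inhibitor
- compound 1 `Nc1ccccc1S(=O)(=O)N1CC(n2cnc3c(Cl)nc(Cl)nc32)OCc2ccccc21` gives 820 nM
- compound 2 `O=[N+]([O-])c1ccc(S(=O)(=O)N2C[C@H](n3cnc4c(Cl)nc(Cl)nc43)OCc3ccccc32)cc1` gives 190 nM
- compound 3 `O=[N+]([O-])c1ccccc1S(=O)(=O)N1CC(n2cnc3c(Cl)nc(Cl)nc32)OCc2ccccc21` gives 383 nM

Compound 3 at 383 nM lies within the scatter of compound 2 at 190 nM and well short of matching compound 1. Going by the values given here, compound 4 `O=[N+]([O-])c1ccc(S(=O)(=O)N2CC(n3cnc4c(Cl)nc(Cl)nc43)OCc3ccccc32)cc1` has 4-nitrophenyl in place of 2-nitrophenyl on a sulfonyl sulfur and has no measurement yet. Among the compounds with values here, the one measured step of a 2.1-fold lower number from compound 1 to compound 3 (0.33 log units; beyond the scatter) is modest and replaces amino with nitro without relocating anything, and it bears only loosely here. The closer guide is compound 2 at 190 nM which also carries 4-nitrophenyl. A small step toward a lower number is expected in this assay (estimated a 1.7-fold lower number from compound 3 to compound 4 (0.22 log units; within the scatter)). Compound 4 is expected at 230 nM (estimated range 110 nM to 480 nM).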

Compound 4, half-maximal inhibitory concentration: 355 nM
Compound 4: middle estimate off by 1.5-fold (0.19 log units), on the low side, and the stated range covers the measured number.
By their numbers in this assay, from the lowest: compounds 2, 4 and 3 (each within the scatter of the next); then compound 1.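

The nitro group's place on the phenyl ring shows no readable effect in this assay: 4-nitrophenyl in place of 2-nitrophenyl on a sulfonyl sulfur gives (a 1.1-fold lower number from compound 3 to compound 4 (0.03 log units; within the scatter)), within the scatter. The step to 4-nitrophenyl from 2-aminophenyl runs the same way as the earlier amino-to-nitro step (a 2.3-fold lower number from compound 1 to compound 4 (0.36 log units; beyond the scatter)). The drawn stereocentre also gives no readable separation (a 1.9-fold higher number from compound 2 to compound 4 (0.27 log units; within the scatter)), and this pair is compared with one caveat: the fact that one of compounds 2 and 4 is drawn with a defined configuration and the other without, at the place where they differ.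

Still open, on these data alone, is whether a carboxylic acid or a methoxy group in place of nitro would shift the number. As far as these compounds go, the opposite configuration at the ring carbon also remains open.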